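The compounds below may be only part of what the source reports. "The series", "measured", "known", "first", "only" and "open" are said of these compounds alone.

Measured so far:
Compound 1 `COc1cc(-c2nccn2C(C)C)cc(OC)c1OC`: > 100000 nM (a limit)
Compound 2 `CCCCCn1ccnc1-c1cc(OC)c(OC)c(OC)c1`: 57900 nM
Compound 3 `COc1cc(-c2nccn2Cc2ccccc2)cc(OC)c1OC`: > 100000 nM (a limit)

All three were tested in a functional assay on MDA-MB-468 cells (Homo sapiens) for antiproliferative activity, read by MTT assay, with a stated time of 72 h; a lower number here means a stronger inhibitor, a higher number a weaker inhibitor. Compound 3 has no number, only a limit, > 100000 nM. Compound 4 `COc1cc(-c2nccn2-c2cccc(C)c2)cc(OC)c1OC` keeps the shared core and differs from it as follows: 3-methylphenyl in place of benzyl on an aromatic nitrogen. In words, 3-methylphenyl stands in place of benzyl on an aromatic nitrogen.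

The measured steps that bear on this are changes to the group on that same nitrogen. One is an at least 1.7-fold lower number from compound 1 to compound 2 (0.23 log units; that floor lies within the scatter), and its floor lies within the scatter. Another is an at least 1.7-fold higher number from compound 2 to compound 3 (0.23 log units; that floor lies within the scatter), whose floor also lies within the scatter. The third, a step that the two limits leave unreadable from compound 1 to compound 3, cannot be read. The set is dominated by the limit of > 100000 nM in this assay, at which 2 of the 3 values shown sit. No step beyond the scatter is therefore expected in this assay, though a small move toward a lower number is possible.

The expected step is an at least 1.1-fold lower number from compound 3 to compound 4 (0.04 log units; that floor lies within the scatter). Compound 4 is estimated at 90000 nM, with an expected range of 30000 nM to 200000 nM, and it may be reported only as a limit.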

Compound 4, half-maximal inhibitory concentration: 22600 nM
The estimate for compound 4 lay 4.0-fold (0.60 log units) above the measured number, outside the stated range (below it).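

Among the compounds shown here, with 3-methylphenyl on the aromatic nitrogen, this assay shows an at least 4.4-fold lower number from compound 3 to compound 4 (0.64 log units; beyond the scatter), so a change at this position now clears the scatter, which no earlier readable step did. For the compounds shown here, the same replacement gives a 2.6-fold lower number from compound 2 to compound 4 (0.41 log units; beyond the scatter) against pentyl, the only earlier group with a measured number, and an at least 4.4-fold lower number from compound 1 to compound 4 (0.64 log units; beyond the scatter) against isopropyl. Benzyl and 3-methylphenyl hold the same atoms, joined differently, so this position separates two groups that the atom count alone does not.

The compounds shown leave open whether the lower number follows from the ring standing directly on the nitrogen or from its methyl group, which an unsubstituted phenyl or a methoxy in place of the methyl would help to separate. How far the steps from the two limit compounds really reach also stays open: the limit of > 100000 nM in this assay, at which 2 of the 4 values shown sit.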